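Swapping an aryloxymethyl for a chlorobenzyl-ethyl amide side chain

The source may hold more compounds than are shown below. What is called first, only, known or untested is meant among the compounds shown, and "the series" means these compounds.

Measured compounds:
- compound 1 `CC(C)C[C@H](N)c1cc(C(F)(F)F)ccc1N1CCN(C(=O)COc2ccc3ccccc3c2)CC1`: 2000 nM
- compound 2 `COc1cc(CC(C)C(=O)N2CCN(c3ccc(C(F)(F)F)cc3[C@@H](N)CC(C)C)CC2)ccc1Cl`: 230 nM
- compound 3 `COc1ccc(OCC(=O)N2CCN(c3ccc(C(F)(F)F)cc3[C@@H](N)CC(C)C)CC2)cc1`: 3800 nM

All three share one core and differ only in the group attached to the amide carbonyl. In an assay on HEK293 cells for displacement of a labelled ligand from Melanocortin receptor 4 (Homo sapiens) (on this read-out higher numbers stand for weaker inhibition and lower numbers for stronger inhibition), compound 3 gives the highest of the three numbers; its gap to compound 1 is within the scatter, while its gap to compound 2 is large, as the step of a 17-fold higher number from compound 2 to compound 3 (1.22 log units; beyond the scatter) shows.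

The unmeasured compound 4 `CC(C)C[C@H](N)c1cc(C(F)(F)F)ccc1N1CCN(C(=O)[C@H](C)Cc2ccc(Cl)cc2)CC1` differs from compound 3 by 1-(4-chlorobenzyl)ethyl in place of (4-methoxyphenoxy)methyl on a carbonyl carbon. This is close to a reversal of the step from compound 2 to compound 3: the group entering compound 4 is the 1-(4-chlorobenzyl)ethyl group, which matches the group of compound 2 apart from a missing methoxy. Going by the values given here, two measured steps bear on it. The step of a 17-fold higher number from compound 2 to compound 3 (1.22 log units; beyond the scatter) went in the opposite direction, and the step of an 8.7-fold lower number from compound 1 to compound 2 (0.94 log units; beyond the scatter) shows the same kind of benzyl-ethyl group giving a clearly lower number than an aryloxymethyl group. A large drop in this assay is therefore expected, though the missing methoxy leaves some uncertainty about its full size.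

Compound 4 is expected to give about 300 nM, with a range of 100 nM to 1000 nM. The expected step is a 13-fold lower number from compound 3 to compound 4 (1.10 log units; beyond the scatter).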

Compound 4, inhibition constant: 31 nM
Estimate against measurement, compound 4: 9.7-fold (0.99 log units) above, outside the stated range (below it).
By their numbers in this assay, from the lowest: compound 4; then compound 2; then compounds 1 and 3 (each within the scatter of the next).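

In this assay, going by these compounds alone, the 1-(4-chlorobenzyl)ethyl group on the carbonyl carbon gives a 120-fold lower number from compound 3 to compound 4 (2.09 log units; beyond the scatter) and a 65-fold lower number from compound 1 to compound 4 (1.81 log units; beyond the scatter), so this position can tolerate a far larger change in the number than the earlier compounds revealed. Compared with the 1-(4-chloro-3-methoxybenzyl)ethyl group, the group without the methoxy gives a 7.4-fold lower number from compound 2 to compound 4 (0.87 log units; beyond the scatter), which shows that the number here depends on the substituents of the benzyl ring and not only on the choice between an aryloxymethyl and a benzyl-ethyl group. Nothing shown here explains why these changes lower the number.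

The compounds shown do not separate the contribution of the chlorine from that of the branching methyl, which a 1-(4-fluorobenzyl)ethyl group or an unbranched 2-(4-chlorophenyl)ethyl group would help to test. From the compounds shown here alone, it also remains open how much the stereocentre matters, as it is defined in the group of compound 4 but not in that of compound 2, so the methoxy may not account for that whole step.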